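A few compounds are considered here, and "the series" means these few. Any claim that something is new, unique, unknown or untested is made for them only; others in the source may bear on it.

Measured in an assay for inhibition of acyl-CoA:cholesterol acyltransferase (Oryctolagus cuniculus), using microsomes; on this read-out lower numbers stand for stronger inhibition and higher numbers for weaker inhibition:
- compound 3 `CCCCCCCCCCCCC(C)(C)C(=O)Nc1c(C)cc(C)c2c1OC(C)(C)C2`: 33 nM
- compound 1 `CCCCCCCCCCC(C)(C)C(=O)Nc1c(C)c([N+](=O)[O-])c(C)c2c1OC(C)(C)C2`: 36 nM
- compound 2 `CCCCCCCCCCC1(C(=O)Nc2c(C)cc(C)c3c2OC(C)(C)C3)CCCC1`: 170 nM

In this assay compound 3 shows the lowest of the three numbers, but compound 1 sits within the scatter of it, so the two cannot be told apart; only compound 2 lies beyond the scatter from compound 3. Compound 4 `Cc1cc(C)c(NC(=O)C(C)(C)CCCc2ccc(CC(C)C)cc2)c2c1CC(C)(C)O2` differs from compound 3 by 4-isobutylphenyl in place of nonyl on a saturated chain carbon, four bonds along the chain from a carbonyl carbon. For the measured compounds named here, no measured pair shows this kind of change, so nothing tells its size directly. The expected step is a 1.8-fold higher number from compound 3 to compound 4 (0.26 log units; within the scatter), a modest move toward a higher number that may well stay within the scatter. Compound 4 is therefore estimated to give 60 nM in this assay, with a range from 15 nM to 250 nM.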

Compound 4, half-maximal inhibitory concentration: 40 nM
Compound 4: the middle estimate sits 1.5-fold (0.18 log units) above what was measured; the measured number falls inside the stated range.
By their numbers in this assay, from the lowest: compounds 3, 1 and 4 (each within the scatter of the next); then compound 2.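

In this assay, for the compounds shown here, a 1.2-fold higher number from compound 3 to compound 4 (0.08 log units; within the scatter) is the first step between compounds that differ in one place, and it lies within the scatter. So on this saturated chain carbon, four bonds along the chain from a carbonyl carbon, 4-isobutylphenyl, with its six-membered aromatic ring, can stand in place of the ringless nonyl without a difference that can be read. Nothing at hand bears on the reason for this result.

Going by these compounds, whether an amine or a carboxylic acid in this place would also stay within the scatter of compound 3 remains open. So does whether 4-isobutylphenyl would give the same result in compound 1.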